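Hydroxypyridinyl in place of fluorophenyl on the shared core

This account rests on a few compounds, and the source may have more. Where it says the series, first, only, none or still open, it means among the compounds named here.

Three compounds on the shared core have been run in an in vitro assay on HEK385-7 cells for displacement of a labelled ligand from prostaglandin D2 receptor 2 (Homo sapiens); on this read-out higher numbers stand for weaker inhibition and lower numbers for stronger inhibition. Compound 1 `O=C(O)Cc1sc(C(c2ccc(F)cc2)c2ccc(F)cc2)nc1-c1cccc(F)c1` gives 1.4 nM, the lowest of the three numbers. Compound 3 `O=C(O)Cc1sc(C(c2ccccc2)c2ccccc2)nc1-c1cccc(F)c1` gives 2.9 nM, a gap to compound 1 that lies beyond the scatter. Compound 2 `O=C(O)Cc1sc(C(c2ccccc2)c2ccc(F)c(F)c2)nc1-c1ccc(F)cc1` gives 10 nM, the furthest from compound 1. Compound 1 therefore stands at the strong end of what has been measured so far.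

Compound 4 `O=C(O)Cc1sc(C(c2ccc(F)cc2)c2ccc(F)cc2)nc1-c1ccnc(O)c1` has not yet been measured in this assay. It differs from compound 1 in one place: 2-hydroxypyridin-4-yl in place of 3-fluorophenyl on an aromatic carbon. Going by the values given here, no pair of measured compounds differs in just one place, so no measured step sets the size of this kind of change, and every measured compound carries a fluorophenyl or phenyl at this position of the core. The expectation rests only on compound 1 giving 1.4 nM and on the change itself.

The step is expected to be a loss of moderate size, a 4.3-fold higher number from compound 1 to compound 4 (0.63 log units; beyond the scatter), likely beyond the scatter but not large. For compound 4 the estimate in this assay is 6 nM, with a range from 1.5 nM to 25 nM.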

Compound 4, half-maximal inhibitory concentration: 68 nM
The estimate for compound 4 lay 11-fold (1.05 log units) below the measured number; the whole stated range lies below it.
By their numbers in this assay, from the lowest: compound 1; then compound 3; then compound 2; then compound 4.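

In this assay, the step from 3-fluorophenyl to 2-hydroxypyridin-4-yl gives a 49-fold higher number from compound 1 to compound 4 (1.69 log units; beyond the scatter), the first single-place change read at this aromatic carbon next to the ring nitrogen. The position is therefore far from indifferent to the group it carries: the change is large even though the heavy-atom count of 7 and the six-membered aromatic ring both stay the same, so what differs is the ring's make-up and substituent. Nothing measured alongside these numbers bears on why the step is this large.

This one step swaps three things at once: a ring carbon gives way to a ring nitrogen, a hydroxy group enters and the fluorine leaves, and the compounds shown do not tell which of these carries the loss. Going by these compounds, a pyridine ring without the hydroxy group, a methoxy group in place of the hydroxy group, or a plain phenyl at this position on the core of compound 1 would begin to pull these apart, and it remains open whether the same change costs as much with other groups at the rest of the core.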